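Quinolin-2-yloxy variant of the dichloropyridazinyloxy ketone

The compounds below may be only part of what the source reports. "The series", "measured", "known", "first", "only" and "open" are said of these compounds alone.

Compound 1 `CC(C)[C@H](NC(=O)COc1cccc2ccccc12)C(=O)N[C@@H](CC(=O)O)C(=O)CSc1nc[nH]n1`: > 200000 nM
Compound 2 `CC(C)[C@H](NC(=O)COc1cccc2ccccc12)C(=O)N[C@@H](CC(=O)O)C(=O)COc1nncc(Cl)c1Cl`: > 200000 nM

In a functional assay on Jurkat cells (Homo sapiens) for inhibition (a lower number here means a stronger inhibitor, a higher number a weaker inhibitor), compound 1 gives > 200000 nM, a limit of the assay and not a number. In this assay compound 2 gives > 200000 nM, likewise only a limit. Both values sit at the limit of > 200000 nM in this assay, at which 2 of the 2 values shown sit, so the step that the two limits leave unreadable from compound 1 to compound 2 cannot be read. Compound 3 `CC(C)[C@H](NC(=O)COc1cccc2ccccc12)C(=O)N[C@@H](CC(=O)O)C(=O)COc1ccc2ccccc2n1` differs from compound 2 by quinolin-2-yl in place of 4,5-dichloropyridazin-3-yl on an oxygen on a saturated carbon. No readable measured step bears on this change, and compound 2 stands only at a limit. Compound 3 is therefore expected to give 200000 nM, range 50000 nM to 400000 nM, most likely reported again as a limit. The expected step of a number no higher from compound 2 to compound 3 (the limit leaves the size open) is nominal only.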

Compound 3, half-maximal inhibitory concentration: > 200000 nM
Compound 3: no number, only a limit; the forecaster's own chance of this, stated with the estimate: 85%; the middle value sits exactly at the limit.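

In this assay compound 3 gives > 200000 nM, a limit of the assay and not a number. Among the compounds shown here, no step among compound 1, compound 2 and compound 3 can be read. The compounds shown leave open how their differing groups rank in inhibition, with every value at one limit: the limit of > 200000 nM in this assay, at which 3 of the 3 values shown sit.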